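Replacing the Amide with a Methyl Ester on the Shared Core

The compounds below may be only part of what the source reports. "The series", "measured", "known", "first", "only" and "open" are said of these compounds alone.

Measured compounds:
Compound 1, `CC(C)NC(=O)c1cc(-c2cccc(OC(=O)NC3CCCCC3)c2)n(-c2ccccc2)n1`, gives 232 nM in an assay on isolated protein for inhibition of Fatty-acid amide hydrolase 1 (Homo sapiens), read by fluorescence, with a stated time of 30 min; on this read-out lower numbers stand for stronger inhibition and higher numbers for weaker inhibition.
Compound 2, `O=C(NC1CCCCC1)Oc1cccc(-c2cc(C(=O)NC3CCCCC3)nn2-c2ccccc2)c1`, gives 288 nM.
Compound 3, `CCN(CC)C(=O)c1cc(-c2cccc(OC(=O)NC3CCCCC3)c2)n(-c2ccccc2)n1`, gives 448 nM.

Compound 3 carries the highest of the three numbers, yet the steps of a 1.9-fold higher number from compound 1 to compound 3 (0.29 log units; within the scatter) and a 1.6-fold higher number from compound 2 to compound 3 (0.19 log units; within the scatter) both lie within the scatter, so the three compounds cannot be ranked. Compound 4, `COC(=O)c1cc(-c2cccc(OC(=O)NC3CCCCC3)c2)n(-c2ccccc2)n1`, differs from compound 3 by methoxy in place of diethylamino on a carbonyl carbon. Among the measured compounds shown here, the steps of a 1.9-fold higher number from compound 1 to compound 3 (0.29 log units; within the scatter) and a 1.6-fold higher number from compound 2 to compound 3 (0.19 log units; within the scatter) touch the same carbonyl carbon but only exchange the amine part; no measured step replaces the amine with an alkoxy group, so the bearing is indirect. Because a 1.2-fold higher number from compound 1 to compound 2 (0.09 log units; within the scatter) and a 1.6-fold higher number from compound 2 to compound 3 (0.19 log units; within the scatter) are all small, compound 4 is expected to give about 500 nM, between 200 nM and 1500 nM, a step of a 1.1-fold higher number from compound 3 to compound 4 (0.05 log units; within the scatter) that is expected to stay near the scatter.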

Compound 4, half-maximal inhibitory concentration: 18 nM
For compound 4 the middle estimate is 28-fold (1.44 log units) above the measured one, outside the stated range (below it).
By their numbers in this assay, from the lowest: compound 4; then compounds 1, 2 and 3 (each within the scatter of the next).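

Putting methoxy on the carbonyl carbon in place of the amine part gives steps beyond the scatter in all three comparisons: a 25-fold lower number from compound 3 to compound 4 (1.40 log units; beyond the scatter) and a 16-fold lower number from compound 2 to compound 4 (1.20 log units; beyond the scatter) and a 13-fold lower number from compound 1 to compound 4 (1.11 log units; beyond the scatter). Among the earlier compounds, exchanging diethylamino, isopropylamino and cyclohexylamino produced only steps within the scatter. For these four compounds, therefore, the large difference in inhibition separates the methoxy compound from the three amides, while the choice among these amines leaves no readable difference.

The compounds shown leave open whether an ethoxy group, a longer alkoxy chain or a carboxylic acid at this carbonyl carbon would keep the low number of compound 4. Nothing measured here gives a reason for the large steps.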